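Nitrophenyl swap from compound 3 to compound 4

The compounds below may be only part of what the source reports. "The series", "measured", "known", "first", "only" and "open" are said of these compounds alone.

In a functional assay on UACC-62 cells (Homo sapiens) for cytotoxicity, read by sulforhodamine B assay (a higher number here means a weaker inhibitor of growth, a lower number a stronger inhibitor of growth), compound 1 `COc1ccc(/C=N\NC(=S)NC(C)(C)CCC[C@](C)(O)[C@@H]2CC=C(C)CC2)cc1` gives 7420 nM and compound 2 `CC1=CC[C@@H]([C@@](C)(O)CCCC(C)(C)NC(=S)N/N=C\c2ccccc2[N+](=O)[O-])CC1` gives 6050 nM, while compound 3 `CC1=CC[C@@H]([C@@](C)(O)CCCC(C)(C)NC(=S)N/N=C\c2cccc([N+](=O)[O-])c2)CC1` gives 7840 nM and so stands within the scatter of both. Compound 4 `CC1=CC[C@@H]([C@@](C)(O)CCCC(C)(C)NC(=S)N/N=C\c2ccc([N+](=O)[O-])cc2)CC1` differs from compound 3 by one change: 4-nitrophenyl in place of 3-nitrophenyl on a carbon with a double bond to nitrogen. Within the data shown here, the closest precedent is 3-nitrophenyl in place of 2-nitrophenyl (a 1.3-fold higher number from compound 2 to compound 3 (0.11 log units; within the scatter)). Replacing 4-methoxyphenyl with either nitrophenyl also stayed within the scatter (a 1.2-fold lower number from compound 1 to compound 2 (0.09 log units; within the scatter); a 1.1-fold higher number from compound 1 to compound 3 (0.02 log units; within the scatter)). In this assay no step beyond the scatter is therefore expected (a 1.1-fold lower number from compound 3 to compound 4 (0.05 log units; within the scatter)). For compound 4 the estimated value is 7000 nM (expected range 3500 nM to 14000 nM).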

Compound 4, concentration for 50% growth inhibition: 20800 nM
Estimate against measurement, compound 4: 3.0-fold (0.47 log units) below; measured number outside the range, above it.
By their numbers in this assay, from the lowest: compounds 2, 1 and 3 (each within the scatter of the next); then compound 4.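

In this assay, among these compounds, 4-nitrophenyl is the first group on this carbon to give a step beyond the scatter (a 2.7-fold higher number from compound 3 to compound 4 (0.42 log units; beyond the scatter); a 3.4-fold higher number from compound 2 to compound 4 (0.54 log units; beyond the scatter)), so the nitrophenyl isomers are no longer all alike. Nitro in place of methoxy also gives such a step (a 2.8-fold higher number from compound 1 to compound 4 (0.45 log units; beyond the scatter)), although 2-nitrophenyl and 3-nitrophenyl stayed within the scatter of 4-methoxyphenyl, so the presence of nitro alone does not account for the result. No measurement shown offers an explanation for this higher number. On these data alone, it remains open whether an amine or a carboxylic acid in place of the nitro of 4-nitrophenyl would give a number like that of compound 4 or one like that of compound 1.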